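The compounds below may be only part of what the source reports. "The series", "measured", "known", "first", "only" and "open" are said of these compounds alone.

Three compounds sharing one core have been examined in a functional assay on L1210 cells (Mus musculus) for cytotoxicity; a lower number here means a stronger inhibitor, a higher number a weaker inhibitor. Compound 1 `Cc1cccc(C)c1NC(=O)/C=C/C(=O)N1C/C(=C\c2ccccc2)C(=O)/C(=C/c2ccccc2)C1` gives 22000 nM in this assay. Compound 3 `O=C(/C=C/C(=O)N1C/C(=C\c2ccccc2)C(=O)/C(=C/c2ccccc2)C1)Nc1ccccc1` gives 3600 nM in this assay; it differs from compound 1 only by phenyl in place of 2,6-dimethylphenyl on an amide-type nitrogen, and the step of a 6.1-fold lower number from compound 1 to compound 3 (0.79 log units; beyond the scatter) lies beyond the usual scatter. Compound 2 `Cc1cccc(C)c1NC(=O)/C=C/C(=O)N1C/C(=C\c2ccc([N+](=O)[O-])cc2)C(=O)/C(=C/c2ccc([N+](=O)[O-])cc2)C1` gives 690 nM in this assay, the lowest of the three numbers; how its core differs from that of compound 1 is not broken down here, and the two values simply show a wide gap between them. Compound 4 `O=C(/C=C/C(=O)N1C/C(=C\c2ccc([N+](=O)[O-])cc2)C(=O)/C(=C/c2ccc([N+](=O)[O-])cc2)C1)Nc1ccccc1` has not yet been measured. It differs from compound 2 by phenyl in place of 2,6-dimethylphenyl on an amide-type nitrogen, the same change that separates compound 1 from compound 3, at a place described in the same words. Among the compounds with values here, for compound 4 the expected step is a 4.6-fold lower number from compound 2 to compound 4 (0.66 log units; beyond the scatter), set somewhat smaller than the earlier step because a 6.1-fold lower number from compound 1 to compound 3 (0.79 log units; beyond the scatter) is the only instance seen and it sits on a different core. Compound 4 is therefore estimated at 150 nM, within a range from 50 nM to 450 nM.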

Compound 4, half-maximal inhibitory concentration: 1800 nM
Beside the measured number, compound 4's estimate is 12-fold (1.08 log units) below it; measured number above the stated range.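

In this assay, the replacement of 2,6-dimethylphenyl by phenyl on an amide-type nitrogen does not carry over from one core to the other, since the new step, a 2.6-fold higher number from compound 2 to compound 4 (0.42 log units; beyond the scatter), runs in the opposite direction to the earlier one, a 6.1-fold lower number from compound 1 to compound 3 (0.79 log units; beyond the scatter). Set side by side, the two steps differ by more than the scatter of such steps: the same change on two cores in this assay, a 6.1-fold lower number (0.79 log units; beyond the scatter) from compound 1 to compound 3 and a 2.6-fold higher number (0.42 log units; beyond the scatter) from compound 2 to compound 4, 16-fold (1.20 log units) apart, beyond the scatter of two such steps. This shows that in these two pairs the outcome of the change depends on the core that carries it, but it does not show which feature of the core is responsible, and two pairs cannot predict the direction or size of the step on any further core.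

The compounds shown leave open whether the reversal is tied to the nitro groups of compound 2 and compound 4 or would also appear with an amine or a methoxy group in their place. They also leave open how an amide nitrogen bearing a longer alkyl chain, such as butyl, would compare with the two aryl groups.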